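Removing the bromo group from compound 3

The source may hold more compounds than are shown below. What is called first, only, known or untested is meant among the compounds shown, and "the series" means these compounds.

Compound 1 `COc1cc2c(cc1OC)C(c1ccc([N+](=O)[O-])cc1)=NNC(=O)C2` — limit in a functional assay on the whole organism with Mus musculus as the target; on this read-out lower numbers stand for an effect already at smaller amounts and higher numbers for an effect only at larger amounts of compound: > 120 umol/kg
Compound 2 `COc1cc2c(cc1OC)C(c1ccc(Cl)cc1)=NNC(=O)C2` — 75.3 umol/kg
Compound 3 `COc1cc2c(cc1OC)C(c1ccc(Br)cc1)=NN(C)C(=S)C2` — 60.4 umol/kg

Of the compounds shown here, three sharing one core have been measured. For compound 1 the result is only a limit of the assay, > 120 umol/kg, and sits at the floor described by the limit of > 120 umol/kg in this assay, at which 1 of the 3 values shown sits. Compound 2 gives 75.3 umol/kg and compound 3 gives 60.4 umol/kg; compound 3 has the lowest of the two numbers, but its gap to compound 2 lies within the scatter, so no order can be read between them.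

Among the measured compounds shown here, the one measured step, an at least 1.5-fold lower number from compound 1 to compound 2 (0.20 log units; that floor lies within the scatter), swaps one group for another on an aromatic carbon, and its floor lies within the scatter. Compound 4 `COc1cc2c(cc1OC)C(c1ccccc1)=NN(C)C(=S)C2` is not yet measured; it differs from compound 3 by hydrogen in place of bromo on an aromatic carbon. For the measured compounds named here, the single step measured so far does not cover a halogen giving way to hydrogen, so the only guide is that changes at this aromatic carbon have not moved the number far. Compound 4 is therefore expected to stay close to compound 3, a step of a 1.2-fold higher number from compound 3 to compound 4 (0.09 log units; within the scatter), with an estimate of 75 umol/kg and a range from 35 umol/kg to 150 umol/kg.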

Compound 4, dose for half-maximal effect: 24.7 umol/kg
For compound 4 the middle estimate is 3.0-fold (0.48 log units) above the measured one; measured number below the stated range.
By their numbers in this assay, from the lowest: compound 4; then compounds 3 and 2 (each within the scatter of the next). At a limit, above all of these: compound 1.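

In this assay the change from 4-bromophenyl to phenyl gives a 2.4-fold lower number from compound 3 to compound 4 (0.39 log units; beyond the scatter), and unlike the earlier step at this aromatic carbon, whose floor lay within the scatter, this one lies beyond it. On the core of compound 3, then, what sits at this carbon does move the number, and the bromo is not needed for the effect in the whole animal. Nothing among the data shown accounts for this step.

On these data alone, whether hydrogen in place of chloro would do the same on the core of compound 2 remains open. So does whether a fluoro, a methoxy or an amine at this carbon would give a number closer to that of compound 4 or to that of compound 3.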